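The source may report more compounds than this note shows. Statements on the series, on what has been measured and on what is new or still open speak of the compounds shown alone.

Series notes. Compound 1 `Cc1ccc2[nH]c(=O)c(-c3nc4cc([N+](=O)[O-])ccc4[nH]3)cc2c1` carries a nitro group on the shared core, and in a functional assay on NCI-H460 cells (Homo sapiens) for cytotoxicity, read by MTT assay, with a stated time of 48 h (on this read-out higher numbers stand for weaker inhibition and lower numbers for stronger inhibition), compound 1 returns only a limit, > 100000 nM. Compound 3 `COc1ccc2[nH]c(=O)c(-c3nc4cc(C)c(C)cc4[nH]3)cc2c1` likewise gives only a limit in this assay, > 100000 nM. Among the compounds with values here, compound 2 `O=c1[nH]c2ccccc2cc1-c1nc2cc(Br)ccc2[nH]1`, the bromo member, is the one compound with a number in this assay, at 16800 nM. Compound 1 thus stands at the limit of > 100000 nM in this assay, at which 2 of the 3 values shown sit.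

Compound 4 `Cc1ccc2[nH]c(=O)c(-c3nc4cc(F)ccc4[nH]3)cc2c1` differs from compound 1 by fluoro in place of nitro on an aromatic carbon. Within the data shown here, no measured step joins a nitro compound to a fluoro compound in this set, so the size of the step can only be inferred from the measured compounds. Compound 2 shows that a bromo compound reaches a number in this assay, 16800 nM. The expected step from compound 1 to compound 4 is toward stronger inhibition, an at least 2.5-fold lower number from compound 1 to compound 4 (0.39 log units; beyond the scatter), though with wide uncertainty and a real chance of another limit. Compound 4 is estimated at 40000 nM, in a range from 12000 nM to 130000 nM.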

Compound 4, half-maximal inhibitory concentration: > 100000 nM
Compound 4: only a limit was reported (the forecaster's own chance of this, stated with the estimate: 40%); middle value at least 2.5-fold (0.39 log units) away from the limit.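

Compound 1 and compound 4 each return only a limit, so the step from nitro to fluoro cannot be read: the limit of > 100000 nM in this assay, at which 3 of the 4 values shown sit.

The compounds shown leave open whether fluoro or nitro on this core gives the stronger inhibition, and by how much.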